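This account rests on a few compounds, and the source may have more. Where it says the series, first, only, none or still open, it means among the compounds named here.

Compound 1 `C[C@H](NC(=O)CN(c1nc(Cl)nc2[nH]cnc12)C1CC1)C(=O)O` gives 48.1% in a functional assay on the whole organism (Tail, strain ICR) with Mus musculus as the target, in the tail flick test, with a stated time of 30 min, at a dose of 25 umol/kg by the oral route; on this read-out lower numbers stand for a weaker effect and higher numbers for a stronger effect at the one dose given.
Compound 2 `CC(C)[C@H](NC(=O)CN(c1nc(Cl)nc2[nH]cnc12)C1CC1)C(=O)O` gives 31.2%.
Compound 3 `CC(C)C[C@H](NC(=O)CN(c1nc(Cl)nc2[nH]cnc12)C1CC1)C(=O)O` gives 23.4%.

Compound 3 sits at the low end of these three numbers; its gap to compound 2 lies within the scatter, so the two cannot be ranked, while its gap to compound 1 lies beyond it. Compound 4 `O=C(O)CNC(=O)CN(c1nc(Cl)nc2[nH]cnc12)C1CC1` differs from compound 3 by hydrogen in place of isobutyl on a saturated chain carbon bound to an amide-type nitrogen and a carbonyl carbon. Among the compounds with values here, the steps that bear on this change are a number 16.9 percentage points lower from compound 1 to compound 2 (beyond the scatter) and a number 24.7 percentage points lower from compound 1 to compound 3 (beyond the scatter), in both of which a larger group at this place went with a lower number, whereas a number 7.8 percentage points lower from compound 2 to compound 3 (within the scatter) stayed within the scatter. Taking the group away entirely is therefore expected to raise the number, giving a number 26.6 percentage points higher from compound 3 to compound 4 (beyond the scatter) in this assay. Compound 4 is thus estimated at 50%, with a range from 30% to 70%.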

Compound 4, a percentage reported as activity, at one dose (the size of the read-out at that dose, not a potency): 32.2%
Compound 4: the middle estimate sits 17.8 percentage points above what was measured; the range from low to high includes it.
By their numbers in this assay, from the lowest: compounds 3, 2 and 4 (each within the scatter of the next); then compound 1.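

In this assay, hydrogen in place of isobutyl gives a number 8.8 percentage points higher from compound 3 to compound 4 (within the scatter), and hydrogen in place of isopropyl gives a number 1 percentage points higher from compound 2 to compound 4 (within the scatter), so these three groups cannot be ranked. Hydrogen in place of methyl gives a number 15.9 percentage points lower from compound 1 to compound 4 (beyond the scatter), so the earlier link between a larger group and a lower number does not extend down to hydrogen, and methyl stands above all three. The effect of a change at this place thus depends on the group it starts from: the same change on two cores in this assay, a number 24.7 percentage points lower (beyond the scatter) from compound 1 to compound 3 and a number 1 percentage points lower (within the scatter) from compound 4 to compound 2, 23.7 percentage points apart, beyond the scatter of two such steps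

From the compounds shown here alone, whether the higher number is particular to methyl remains open, as ethyl or aminomethyl on this carbon could show.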